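The source may report more compounds than this note shows. Statements on the series, on what has been measured and on what is new or still open speak of the compounds shown alone.

Compound 1 `C[C@@H]1CN(c2sc(C(F)(F)F)nc2-c2nc3ccccc3[nH]2)CCN1C(=O)Cn1cc(Cl)cn1` gives 251 nM in a functional assay on Venous blood for antagonist activity at C-X-C chemokine receptor type 3 (Homo sapiens), read by flow cytometry, with a stated time of 30 min, in the presence of a further agent that is not named here; on this read-out lower numbers stand for stronger inhibition and higher numbers for weaker inhibition.
Compound 2 `Cc1nc(C)n(CC(=O)N2CCN(c3sc(C(F)(F)F)nc3-c3nc4ccc(OC5CNC5)cc4[nH]3)C[C@H]2C)n1` gives 580 nM in this assay.
Compound 3 `C[C@@H]1CN(c2sc(C(F)(F)F)nc2-c2nc3ccc(CO)cc3[nH]2)CCN1C(=O)Cn1cnc2cccnc21` gives 92.4 nM in this assay.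

Among these three numbers in this assay, compound 1 stands second highest. Its nearest neighbour is compound 2, whose number is higher by a margin beyond the usual scatter, and its furthest is compound 3, whose number is lower, again beyond the scatter. No two of the measured compounds differ in only one place, so no single step can be read from them, and compounds 2 and 3 differ from compound 1 both in the group on the saturated chain carbon bound to the carbonyl carbon and elsewhere on the shared core.

Compound 4 `Cc1nn(CC(=O)N2CCN(c3sc(C(F)(F)F)nc3-c3nc4ccccc4[nH]3)C[C@H]2C)cc1CN(C)C` has not been measured. It differs from compound 1 in one place: 4-((dimethylamino)methyl)-3-methyl-1H-pyrazol-1-yl in place of 4-chloro-1H-pyrazol-1-yl on a saturated chain carbon bound to a carbonyl carbon. Within the data shown here, nothing among the measured compounds isolates this change, so the expectation rests on compound 1 alone. The step of a 1.2-fold higher number from compound 1 to compound 4 (0.08 log units; within the scatter) is expected to be small, with no clear direction beyond the scatter. Compound 4 is therefore estimated at 300 nM in this assay, within a range from 100 nM to 900 nM.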

Compound 4, half-maximal inhibitory concentration: 330 nM
Beside the measured number, compound 4's estimate is 1.1-fold (0.04 log units) below it; measured number inside the range.
By their numbers in this assay, from the lowest: compound 3; then compounds 1, 4 and 2 (each within the scatter of the next, the first and the last beyond it).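

In this assay, among these compounds, the step of a 1.3-fold higher number from compound 1 to compound 4 (0.12 log units; within the scatter) is the first comparison in this set that isolates a single place, and it lies within the usual scatter. On a saturated chain carbon bound to a carbonyl carbon, 4-chloro-1H-pyrazol-1-yl can therefore give way to 4-((dimethylamino)methyl)-3-methyl-1H-pyrazol-1-yl, which has more heavy atoms, an added nitrogen and no chlorine, without a difference this read-out can separate from repeat measurement. No measured property is available to bear on this result.

The methyl and the (dimethylamino)methyl enter together, so the compounds shown do not separate them, and whether the same exchange holds on the other cores seen in compounds 2 and 3 stays open. Going by these compounds, how a carboxylic acid or a morpholine in place of the dimethylamino group would read at this place is also open.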